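The source may report more compounds than this note shows. Statements on the series, on what has been measured and on what is new or still open speak of the compounds shown alone.

Of the compounds shown here, two have so far been tested in a functional assay on SK-OV-3 cells (Homo sapiens) for cytotoxicity, read by MTT assay, with a stated time of 48 h (on this read-out lower numbers stand for stronger inhibition and higher numbers for weaker inhibition), and neither gave a number. Compound 1 `Cc1ccc2[nH]c(=O)c(-c3nc4cc([N+](=O)[O-])ccc4[nH]3)cc2c1` reached only the limit of > 100000 nM. Compound 2 `COc1ccc2[nH]c(=O)c(-c3nc4cc(F)ccc4[nH]3)cc2c1` likewise reached only the limit of > 100000 nM. Within the data shown here, both values thus sit at the limit of > 100000 nM in this assay, at which 2 of the 2 values shown sit, so no step between measured compounds can be drawn. Compound 3 `O=c1[nH]c2ccccc2cc1-c1nc2cc(F)ccc2[nH]1` differs from compound 2 by hydrogen in place of methoxy on an aromatic carbon. Since the available values are limits, no shift beyond the usual scatter is expected from this change. Compound 3 is therefore estimated at 100000 nM, within 50000 nM to 200000 nM. The expected step is a number no higher from compound 2 to compound 3 (the limit leaves the size open), none beyond scatter.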

Compound 3, half-maximal inhibitory concentration: 18300 nM
Beside the measured number, compound 3's estimate is 5.5-fold (0.74 log units) above it; measured number below the stated range.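

In this assay, hydrogen in place of methoxy on this aromatic carbon gives an at least 5.4-fold lower number from compound 2 to compound 3 (0.73 log units; beyond the scatter). Among these compounds, this shows that the group at this position can change the read-out, and compound 3 is the first compound here with a measured number rather than a limit. Compound 2 offers only a limit as a starting point, so the full size of the step is unknown: the limit of > 100000 nM in this assay, at which 2 of the 3 values shown sit.

On these data alone, whether an amine or a longer chain such as ethoxy on this carbon would give a number like that of compound 3 remains open. So does whether the change would have a similar effect on a core carrying a nitro group instead of fluorine.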